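Notes on the permeability series toward compound 4

The source may report more compounds than this note shows. Statements on the series, on what has been measured and on what is new or still open speak of the compounds shown alone.

Compound 1 `COc1ccc(F)cc1CNCCCNc1ccnc2cc(C3CCCCC3)ccc12` gives 23 10^-6 cm/s in an ADME assay for permeability, using PAMPA, with a stated time of 30 min, at pH 7.4; on this read-out lower numbers stand for lower permeability and higher numbers for higher permeability. Compound 2 `COc1ccc(F)cc1CNCCCNc1ccnc2cc(Cc3ccc(F)cc3)ccc12` gives 23 10^-6 cm/s and compound 3 `COc1ccc(F)cc1CNCCCNc1ccnc2cc(Cc3ccc(C#N)cc3)ccc12` gives 23 10^-6 cm/s, so compound 1 stands level with both, and the steps of no change at the digits printed from compound 1 to compound 2 (within the scatter), no change at the digits printed from compound 1 to compound 3 (within the scatter) and no change at the digits printed from compound 2 to compound 3 (within the scatter) all lie within the scatter. Compound 4 `c1coc(CNCCCNc2ccnc3cc(C4CCCCC4)ccc23)c1` differs from compound 1 by furan-2-yl in place of 5-fluoro-2-methoxyphenyl on a saturated chain carbon bound to an amine nitrogen. For the measured compounds named here, none of the measured steps touches this part of the molecule; all three alter the group on an aromatic carbon, and each left this assay unchanged. There is thus no measured guide for the change to compound 4, and the expected step is a 1.2-fold lower number from compound 1 to compound 4 (0.06 log units; within the scatter), at most modest and possibly none beyond the scatter. Compound 4 is expected to give 20 10^-6 cm/s, within 11 10^-6 cm/s to 36 10^-6 cm/s.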

Compound 4, apparent permeability: 23 10^-6 cm/s
Compound 4: middle estimate off by 1.2-fold (0.06 log units), on the low side; measured number inside the range.
By their numbers in this assay, from the lowest: compounds 1, 2, 3 and 4 (each within the scatter of the next).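

The earlier steps shown here all altered the group on an aromatic carbon, whereas furan-2-yl in place of 5-fluoro-2-methoxyphenyl on a saturated chain carbon bound to an amine nitrogen gives no change at the digits printed from compound 1 to compound 4 (within the scatter) in this assay, so this second place has also left the read-out flat. With cyclohexyl retained, the five-membered aromatic ring reads level with the substituted six-membered one. No measured evidence accounts for this result.

As far as these compounds go, whether an amine or a carboxylic acid on this same carbon would also read level remains open. So does whether the furan-2-yl change holds with 4-fluorobenzyl in place of cyclohexyl.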